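The compounds below may be only part of what the source reports. "The series", "measured", "known", "first", "only" and "open" are said of these compounds alone.

Compound 1 `O=[N+]([O-])c1cccc(NS(=O)(=O)c2ccccc2)c1` and compound 2 `COc1ccc(S(=O)(=O)Nc2cccc([N+](=O)[O-])c2)cc1` share one core. In an ADME assay, compound 1 gives 7.93, while compound 2 gives 8.44. The change between them is hydrogen in place of methoxy on an aromatic carbon, and it made the number go a number 0.51 log units lower from compound 2 to compound 1 (beyond the scatter). Compound 3 `COc1ccc(S(=O)(=O)Nc2ccc(C)cc2)cc1` is built on another core; how its core differs from that of compound 2 is not broken down here. In this assay compound 3 gives 9.8, the highest of the three numbers. Compound 4 `Cc1ccc(NS(=O)(=O)c2ccccc2)cc1` has not been measured yet. It differs from compound 3 by hydrogen in place of methoxy on an aromatic carbon, the same change that led from compound 2 to compound 1. Since that earlier step was a number 0.51 log units lower from compound 2 to compound 1 (beyond the scatter), a step of about the same size is expected, a number 0.50 log units lower from compound 3 to compound 4 (beyond the scatter). Compound 4 is therefore estimated at 9.3, most likely between 9 and 9.6.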

Compound 4, acid dissociation constant: 9.34
For compound 4 the middle estimate is 0.04 log units below the measured one; low and high end bracket the measured number.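

In this assay, exchanging methoxy for hydrogen gives a number 0.46 log units lower from compound 3 to compound 4 (beyond the scatter). Set beside the earlier step, the two results agree in size: the same change on two cores in this assay, a number 0.51 log units lower (beyond the scatter) from compound 2 to compound 1 and a number 0.46 log units lower (beyond the scatter) from compound 3 to compound 4, 0.05 log units apart, within the scatter of two such steps. Going by these compounds alone, this shows that the change carried over between these two cores, but with only two pairs it does not show that it would behave the same way on any other core, nor why the step has this size.

The compounds shown leave open what other groups at this place, such as an amine or a carboxylic acid, would do to the number. On these data alone, whether the step would stay the same with a longer chain in place of methoxy also remains open.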